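The compounds below may be only part of what the source reports. "The series", "measured", "known", "first", "only" and "open" are said of these compounds alone.

Compound 2 `COC(=O)c1cc(-c2cccc(NC(=O)c3ccc(/C=C/C(=O)c4ccc(Br)cc4)cc3)c2)on1` was examined in an ADME assay on Vero cells (Chlorocebus sabaeus) for cytotoxicity, read by MTT assay, with a stated time of 72 h; a higher number here means that more compound is tolerated, a lower number that less compound is tolerated. For compound 2 the outcome is a limit of the assay, > 20 ug/mL, and not a single number. Within the data shown here, compound 1 `CCOC(=O)c1nnn(-c2cccc(NC(=O)c3ccc(/C=C/C(=O)c4ccc(Cl)cc4)cc3)c2)c1C` stands in this assay as "not determined" (no result reported), so no step between two measured compounds can be drawn. Compound 3 `COC(=O)c1cc(-c2cccc(NC(=O)c3ccc(/C=C/C(=O)c4cccc([N+](=O)[O-])c4)cc3)c2)on1` differs from compound 2 by 3-nitrophenyl in place of 4-bromophenyl on a carbonyl carbon. Because compound 2 already rests at the limit of > 20 ug/mL in this assay, at which 1 of the 2 values shown sits, the expected shift in this assay is none beyond the usual scatter, a step that the limit leaves unreadable from compound 2 to compound 3. Compound 3 is therefore estimated at 25 ug/mL, with a range from 10 ug/mL to 60 ug/mL, most likely again reported as a limit.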

Compound 3, half-maximal cytotoxic concentration: > 40 ug/mL
Compound 3 was reported as a limit; the forecaster's own chance of this, stated with the estimate: 65%; at least 1.6-fold (0.20 log units) between middle value and limit.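

Among these compounds, compound 2 and compound 3 each stand in this assay as a limit of the assay, and no step between them can be read. The compounds shown leave open whether 3-nitrophenyl in place of 4-bromophenyl on a carbonyl carbon changes tolerance at all.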